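The compounds below may be only part of what the source reports. "The series", "measured", "known", "first", "only" and "open" are said of these compounds alone.

The measured compounds and their values in a toxicity assay on MDCK cells (Canis lupus familiaris) for cytotoxicity, read by crystal violet staining, with a stated time of 48 h; on this read-out higher numbers stand for lower toxicity in this test and lower numbers for higher toxicity in this test:

compound 1, `Cc1ccc2[nH]c(=O)c(CN(Cc3ccccc3)Cc3ccc(C(C)(C)C)cc3)cc2c1`, gives > 5000 nM, a limit of the assay and not a number.
compound 2, `Cc1ccc2[nH]c(=O)c(CN(Cc3ccc(OC(F)F)cc3)Cc3ccc(C(C)(C)C)cc3)cc2c1`, gives > 5000 nM, again a limit.
compound 3, `Cc1ccc2[nH]c(=O)c(CN(Cc3ccc(SC(F)F)cc3)Cc3ccc(C(C)(C)C)cc3)cc2c1`, gives > 5000 nM, again a limit.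

The three compounds share one core and one amine nitrogen; they differ only in what sits on one aromatic carbon of one of the benzyl groups: hydrogen, difluoromethoxy or (difluoromethyl)sulfanyl. Since every value sits at the limit of > 5000 nM in this assay, at which 3 of the 3 values shown sit, none of the steps between them can be read: a step that the two limits leave unreadable from compound 1 to compound 2, a step that the two limits leave unreadable from compound 1 to compound 3 and a step that the two limits leave unreadable from compound 2 to compound 3. Compound 3 therefore stands exactly where the other two stand, at the limit, and no ordering among the three is possible.

Compound 4, `COc1ccc(C(C)N(Cc2ccc(C(C)(C)C)cc2)Cc2cc3cc(C)ccc3[nH]c2=O)cc1Cl`, is not yet measured. It differs from compound 3 in one place: 1-(3-chloro-4-methoxyphenyl)ethyl in place of 4-((difluoromethyl)sulfanyl)benzyl on an amine nitrogen.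

Within the data shown here, no measured step bears on this change in a readable way, so the expectation rests only on the fact that all three measured compounds sit at the limit of this assay. Compound 4 is therefore expected to remain low in toxicity, at about 10000 nM, between 4000 nM and 30000 nM, meaning an expected step that the limit leaves unreadable from compound 3 to compound 4 that stays within the scatter.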

Compound 4, half-maximal cytotoxic concentration: > 10000 nM
Compound 4 ended at the assay's limit; the forecaster's own chance of this, stated with the estimate: 80%; the middle value lies on the limit itself.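

In this assay compound 4 gives > 10000 nM, a limit of the assay and not a number. Among these compounds, compound 1, compound 2 and compound 3 also stand only at limits, so no step from any of them to compound 4 can be read. The compounds shown leave open where the half-maximal cytotoxic concentration of any of the four actually lies, and whether the changes on the amine nitrogen shift it at all.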